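Working notes: methoxy in place of fluoro

A few compounds are considered here, and "the series" means these few. Any claim that something is new, unique, unknown or untested is made for them only; others in the source may bear on it.

compound 1 (`O=C(CCCCC(S)CCS)Nc1ccc(Cl)cc1`) ("not active" (no number reported))
compound 2 (`O=C(CCCCC(S)CCS)Nc1ccc(F)cc1`) (5.64%)

For the measured compounds named here, in a functional assay on NCI-H460 cells (Homo sapiens) for inhibition, read by MTT assay, with a stated time of 24 h, tested at 0.1 ug/mL (on this read-out lower numbers stand for less inhibition of growth and higher numbers for more inhibition of growth at the one concentration tested), compound 2 holds the only number so far (5.64%), and compound 1 gave no number to compare it with. Compound 3 (`COc1ccc(NC(=O)CCCCC(S)CCS)cc1`) carries methoxy in place of fluoro on an aromatic carbon. Going by the values given here, no measured step sizes this change, so in this assay no shift beyond the usual scatter is expected, in either direction. The estimated a number 0.6 percentage points lower from compound 2 to compound 3 (within the scatter) stays within that scatter. Compound 3 is expected at 5% (estimated range 0% to 15%).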

Compound 3, percent growth inhibition at one concentration: 5.69%
Compound 3: middle estimate off by 0.7 percentage points, on the low side, and the stated range covers the measured number.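

In this assay, for the compounds shown here, methoxy in place of fluoro on an aromatic carbon para to a large group gives a number 0.1 percentage points higher from compound 2 to compound 3 (within the scatter), the first measured step. At this position, then, the larger group and its hydrogen-bond acceptor bring no shift beyond the usual scatter. Nothing available explains why the two numbers match.

From the compounds shown here alone, whether an amine or a carboxylic acid at this position would move the number beyond the scatter remains open. With no number for compound 1, chloro cannot be sized against fluoro or methoxy.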